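A few compounds are considered here, and "the series" means these few. Any claim that something is new, unique, unknown or untested is made for them only; others in the source may bear on it.

Measured so far:
compound 1 `O=C(Nc1cc(Sc2ncn[nH]2)c(O)c2ccccc12)c1ccc2ccccc2c1` — 41.6%
compound 2 `O=C(/C=C/c1ccccc1)Nc1cc(Sc2ncn[nH]2)c(O)c2ccccc12` — 26.2%

In an assay on isolated protein for inhibition of RAC-alpha serine/threonine-protein kinase (Homo sapiens), read by fluorescence, with a stated time of 30 min, tested at 10 uM (on this read-out higher numbers stand for more inhibition at the one concentration tested (going by the name of the read-out) and lower numbers for less inhibition), compound 2 stands lowest of the two numbers, its nearest neighbour being compound 1, whose value sits higher by a number 15.4 percentage points lower from compound 1 to compound 2 (beyond the scatter).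

Compound 3 `COc1ccc(C(=O)Nc2cc(Sc3ncn[nH]3)c(O)c3ccccc23)cc1` is not yet measured. It differs from compound 2 in one place: 4-methoxyphenyl in place of 2-phenylethenyl on a carbonyl carbon. Among the compounds with values here, the only step on record that bears on a change at this carbonyl carbon is the one from compound 1 to compound 2, a number 15.4 percentage points lower from compound 1 to compound 2 (beyond the scatter), where a six-membered aromatic ring of carbon only, as part of naphthalen-2-yl, gave way to 2-phenylethenyl. Compound 3 returns a six-membered aromatic ring of carbon only directly on the carbonyl carbon, now as 4-methoxyphenyl, so a step back in the direction of compound 1 is expected, though with no measured aryl-for-alkenyl swap of this exact kind, its size is uncertain. The expected step is a number 9.8 percentage points higher from compound 2 to compound 3 (within the scatter). Compound 3 is estimated at 36%, with a range of 18% to 54%.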

Compound 3, a percentage reported as inhibition, at one concentration (the size of the read-out at that concentration, not a potency): 30.8%
For compound 3 the middle estimate is 5.2 percentage points above the measured one; the range from low to high includes it.
By their numbers in this assay, from the lowest: compounds 2 and 3 (each within the scatter of the next); then compound 1.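

In this assay, placing 4-methoxyphenyl instead of 2-phenylethenyl on the carbonyl carbon gives a number 4.6 percentage points higher from compound 2 to compound 3 (within the scatter), so this read-out does not separate these two groups. Placing 4-methoxyphenyl instead of naphthalen-2-yl gives a number 10.8 percentage points lower from compound 1 to compound 3 (beyond the scatter), so a six-membered aromatic ring of carbon only on the carbonyl carbon does not by itself bring the number back to that of compound 1, which remains the highest of the three. No measurement at hand accounts for either step.

As far as these compounds go, the part played by the methoxy group remains open, as a plain phenyl or a 4-chlorophenyl on this carbonyl carbon could show. From the compounds shown here alone, it is also open whether a second fused ring other than that of naphthalen-2-yl, a butyl chain or a group carrying a carboxylic acid would hold, raise or lower the number at this position.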